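Ring-Opened Dithiol Analogues in a Hepatoma Cell Growth Assay

This account rests on a few compounds, and the source may have more. Where it says the series, first, only, none or still open, it means among the compounds named here.

The study compares four amides that share a five-carbon chain ending in a sulfur-bearing group but differ in the aryl amine and in whether the two sulfur atoms are joined in a ring or left as free thiols.

Compound 1 `O=C(CCCCC1CCSS1)Nc1ccc([N+](=O)[O-])c(C(F)(F)F)c1` carries a nitro and a trifluoromethyl group on its aryl ring and is read in a functional assay on Bel-7402 cells (Homo sapiens) for inhibition, read by MTT assay, with a stated time of 24 h, tested at 1 ug/mL (on this read-out lower numbers stand for less inhibition of growth and higher numbers for more inhibition of growth at the one concentration tested), where compound 1 gives 7.46%. Compound 2 `O=C(CCCCC1CCSS1)Nc1cccc2ccccc12` has a bicyclic aromatic amine instead; in this assay compound 2 gives 9.55%. The difference between these two cores is not broken down here.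

Compound 3 `O=C(CCCCC(S)CCS)Nc1ccc([N+](=O)[O-])c(C(F)(F)F)c1` is derived from compound 1 by the change (a group of 5 heavy atoms (3 carbon, 2 sulfur; no ring) in place of a group of 5 heavy atoms (3 carbon, 2 sulfur; one five-membered non-aromatic ring with 2 hetero atoms), on a saturated chain carbon, four bonds along the chain from a carbonyl carbon). In this assay compound 3 gives 0.68%, a step of a number 6.8 percentage points lower from compound 1 to compound 3 (within the scatter).

Compound 4 `O=C(CCCCC(S)CCS)Nc1cccc2ccccc12` stands in the same relation to compound 2, through the change (a group of 5 heavy atoms (3 carbon, 2 sulfur; no ring) in place of a group of 5 heavy atoms (3 carbon, 2 sulfur; one five-membered non-aromatic ring with 2 hetero atoms), on a saturated chain carbon, four bonds along the chain from a carbonyl carbon). The place is the same in both pairs, so the change is the same.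

For compound 4 the expected step is a number 6.1 percentage points lower from compound 2 to compound 4 (within the scatter), resting on the earlier step of a number 6.8 percentage points lower from compound 1 to compound 3 (within the scatter) seen for the same change. Compound 4 is therefore estimated at 3.5% in this assay, with a range from -6% to 13% expected to cover most repeat readings.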

Compound 4, percent growth inhibition at one concentration: 0.69%
Beside the measured number, compound 4's estimate is 2.8 percentage points above it, and the stated range covers the measured number.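

In this assay, among these compounds, putting the 1,3-disulfanylpropyl group in place of the five-membered ring on the core of compound 2 gives a step of a number 8.9 percentage points lower from compound 2 to compound 4 (within the scatter), and this step can be set directly beside the one seen for the same change on the core of compound 1: the same change on two cores in this assay, a number 6.8 percentage points lower (within the scatter) from compound 1 to compound 3 and a number 8.9 percentage points lower (within the scatter) from compound 2 to compound 4, 2.1 percentage points apart, within the scatter of two such steps So far as these two pairs can tell, the change reads the same on both cores, and nothing in them suggests that the aryl amine alters what the swap does to this read-out. They do not show that the swap has a real effect on growth inhibition, since each step on its own stays within the scatter, and agreement between two small steps from a single concentration in a single assay is weak support for carrying the change to further cores.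

The compounds shown leave open how the same swap would read on a core bearing an amine or a carboxylic acid on the aryl ring, or on a compound with a longer chain. They also leave open whether the ring and the free thiols would separate at other concentrations, where the readings might stand further from the scatter.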